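An isomer pair in an antiproliferative series

The compounds below may be only part of what the source reports. "The series", "measured", "known", "first", "only" and "open" are said of these compounds alone.

Of the compounds shown here, three sharing one core have been measured in a functional assay on MCF7 cells (Homo sapiens) for antiproliferative activity, read by MTT assay, with stated times of 24 h and 72 h; on this read-out lower numbers stand for stronger inhibition and higher numbers for weaker inhibition. Compound 1 `COc1cc(N2C(=O)[C@@H](Oc3ccccc3)[C@H]2c2ccc([S+](C)[O-])cc2)cc(OC)c1OC` gives 20000 nM, compound 2 `COc1cc(N2C(=O)[C@@H](Oc3ccccc3)[C@H]2c2ccc(O)cc2)cc(OC)c1OC` gives 48000 nM, and compound 3 `COc1ccc([C@@H]2[C@H](Oc3ccccc3)C(=O)N2c2cc(OC)c(OC)c(OC)c2)c([N+](=O)[O-])c1O` gives 89000 nM. Compound 3 shares the upper end of these numbers with one other member of the set. That gap is a 1.9-fold higher number from compound 2 to compound 3 (0.27 log units; within the scatter), while the wider gap is a 4.5-fold higher number from compound 1 to compound 3 (0.65 log units; beyond the scatter).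

Compound 4 `COc1cc(N2C(=O)[C@@H](Oc3ccccc3)[C@H]2c2cc(O)c(OC)c([N+](=O)[O-])c2)cc(OC)c1OC` has not yet been measured in this assay. Compared with compound 3, it has a group of 12 heavy atoms (7 carbon, 1 nitrogen, 4 oxygen; one six-membered aromatic ring of carbon only) in place of a group of 12 heavy atoms (7 carbon, 1 nitrogen, 4 oxygen; one six-membered aromatic ring of carbon only), on a saturated ring carbon. The two have the same atoms, joined differently, and the changed group sits next to the ring nitrogen of the four-membered ring.

Within the data shown here, no measured step rearranges atoms in this way, so the evidence is indirect. Changes to that group among the measured compounds were modest at most: a 2.4-fold higher number from compound 1 to compound 2 (0.38 log units; beyond the scatter) is the remaining example, alongside the two gaps above. A rearrangement that keeps every atom is therefore expected to give no step beyond the scatter, with no firm direction. The estimated step is a 1.5-fold lower number from compound 3 to compound 4 (0.17 log units; within the scatter). Compound 4 is estimated at 60000 nM, with an expected range of 15000 nM to 150000 nM.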

Compound 4, half-maximal inhibitory concentration: 69000 nM
Compound 4: middle estimate off by 1.2-fold (0.06 log units), on the low side; measured number inside the range.
By their numbers in this assay, from the lowest: compound 1; then compounds 2, 4 and 3 (each within the scatter of the next).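

In this assay, compound 4 gives the first direct view of a rearrangement that keeps every atom of the group on the saturated ring carbon next to the ring nitrogen: a 1.3-fold lower number from compound 3 to compound 4 (0.11 log units; within the scatter) stays small, so here the change in how these atoms are joined leaves the two numbers indistinguishable. The same holds against a much smaller group, since a 1.4-fold higher number from compound 2 to compound 4 (0.16 log units; within the scatter) also does not separate the compounds, while a 3.5-fold higher number from compound 1 to compound 4 (0.54 log units; beyond the scatter) adds a third step beyond the scatter from compound 1, which now stands apart from all three others at this position. No measurement at hand accounts for these steps or for the place of compound 1.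

The compounds shown leave open whether a group such as an amine or a carboxylic acid on the aromatic ring at this position would bring the number lower than that of compound 1, or would stay with the other three. As far as these compounds go, the phenoxy group and the 3,4,5-trimethoxyphenyl group are the same in all four compounds, so what replacing either with, for example, a longer chain would do remains unknown.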